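This account rests on a few compounds, and the source may have more. Where it says the series, first, only, none or still open, it means among the compounds named here.

Measured compounds:
- compound 1, `Cc1nn2c(O)cc(N3CCOCC3=O)nc2c1Cc1cccc(C(F)(F)F)c1C`, in an assay on isolated protein for inhibition of phosphatidylinositol 4,5-bisphosphate 3-kinase catalytic subunit beta isoform (Homo sapiens) (on this read-out lower numbers stand for stronger inhibition and higher numbers for weaker inhibition), gives 316 nM
- compound 2, `Nc1nn2c(O)cc(C3CCOCC3)nc2c1Cc1cccc(Cl)c1Cl`, gives in this assay 7.94 nM
- compound 3, `Cc1nn2ccc(C3CCOCC3)nc2c1Cc1cccc(C(F)(F)F)c1C`, gives in this assay 794 nM

Among the three measured compounds, compound 3 stands at the highest number, which in this assay means the weakest inhibition. Its nearest neighbour on the scale is compound 1, whose number is lower by a gap that lies beyond the usual scatter; compound 2 is furthest away, with a much lower number that marks it as the strongest inhibitor of the three. Compounds 1 and 2 each differ from compound 3 in more than one place. No single change can be read off from these pairs.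

Compound 4, `Cc1nn2c(NCCO)cc(C3CCOCC3)nc2c1Cc1cccc(C(F)(F)F)c1C`, is the unmeasured compound. It carries (2-hydroxyethyl)amino in place of hydrogen on an aromatic carbon. Since no comparable single change is shown between measured compounds, the size of this step cannot be taken from the data; the two measured compounds with a substituent at that place, compound 1 at 316 nM and compound 2 at 7.94 nM, both sit lower than compound 3, so a move toward stronger inhibition seems more likely than the reverse. The step from compound 3 to compound 4 is estimated at a 3.2-fold lower number from compound 3 to compound 4 (0.50 log units; beyond the scatter). Compound 4 is expected to give about 250 nM, with a range from 80 nM to 800 nM.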

Compound 4, half-maximal inhibitory concentration: 1260 nM
Compound 4: the middle estimate sits 5.0-fold (0.70 log units) below what was measured, outside the stated range (above it).
By their numbers in this assay, from the lowest: compound 2; then compound 1; then compounds 3 and 4 (each within the scatter of the next).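

In this assay, among these compounds, putting (2-hydroxyethyl)amino in place of hydrogen on this aromatic carbon gives a 1.6-fold higher number from compound 3 to compound 4 (0.20 log units; within the scatter) and so provides the first comparison in this set that differs in only one place. It shows that this carbon, opposite the ring nitrogen, can carry a group of 4 heavy atoms with no ring while the number stays within the usual scatter of repeated measurements, so this step shows no real difference in inhibition of the enzyme. Nothing measured here offers an explanation for this result.

Still open, on these data alone, is how other groups on this carbon would read in this assay and whether a plain amine, a methoxy group or a longer chain such as (3-hydroxypropyl)amino would also leave the number within the scatter. Compounds 1 and 2 differ from compound 3 in more than one place, so the part played by their own substituents at this carbon remains unresolved, as does whether the step seen here would read the same with other groups elsewhere on the core.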